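A few compounds are considered here, and "the series" means these few. Any claim that something is new, unique, unknown or untested is made for them only; others in the source may bear on it.

Of the compounds shown here, three have so far been measured in an ADME assay for permeability, using PAMPA, with a stated time of 30 min, at pH 7.4; on this read-out higher numbers stand for higher permeability and lower numbers for lower permeability. Compound 1 `COc1cccc(CNCCCNc2ccnc3cc(-c4ccc(C(F)(F)F)cc4)ccc23)c1O` gives 237 10^-6 cm/s, compound 2 `COc1ccc(F)cc1CNCCCNc1ccnc2cc(CCc3ccccc3)ccc12` gives 23 10^-6 cm/s, and compound 3 `COc1ccc(F)cc1CNCCCNc1ccnc2cc(Oc3ccc(F)cc3)ccc12` gives 317 10^-6 cm/s, the highest of the three numbers, although the gap to compound 1 lies within the usual scatter. Compound 4 `COc1ccc(F)cc1CNCCCNc1ccnc2cc(-c3ccc(C(F)(F)F)cc3)ccc12` has not yet been measured; it differs from compound 3 in a single place: 4-(trifluoromethyl)phenyl in place of 4-fluorophenoxy on an aromatic carbon. Among the measured compounds shown here, the only measured step, a 14-fold higher number from compound 2 to compound 3 (1.14 log units; beyond the scatter), concerns a different exchange and gives no direct guide. Compound 1 carries the same 4-(trifluoromethyl)phenyl group, and its number in this assay sits close to that of compound 3. The step of a 1.3-fold lower number from compound 3 to compound 4 (0.10 log units; within the scatter) is therefore expected to remain within the scatter. Compound 4 is estimated to give 250 10^-6 cm/s, with a range from 120 10^-6 cm/s to 500 10^-6 cm/s.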

Compound 4, apparent permeability: 237 10^-6 cm/s
Compound 4: middle estimate off by 1.1-fold (0.02 log units), on the high side, within the range that was stated.
By their numbers in this assay, from the lowest: compound 2; then compounds 1, 4 and 3 (each within the scatter of the next).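

In this assay the aromatic carbon takes 4-(trifluoromethyl)phenyl as well as 4-fluorophenoxy, with a 1.3-fold lower number from compound 3 to compound 4 (0.13 log units; within the scatter) and so a group with no oxygen atom serves here too. Phenethyl now stands apart from two groups rather than one, with a 10-fold higher number from compound 2 to compound 4 (1.01 log units; beyond the scatter) as a second large step. With 4-(trifluoromethyl)phenyl held fixed, 5-fluoro-2-methoxyphenyl can replace 2-hydroxy-3-methoxyphenyl, with no change at the digits printed from compound 1 to compound 4 (within the scatter) on this read-out. On these data alone, whether an amine or a carboxylic acid on this aromatic carbon would keep the number stays open. Nothing at hand explains these numbers.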